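A few compounds are considered here, and "the series" means these few. Any claim that something is new, unique, unknown or untested is made for them only; others in the source may bear on it.

Compound 1 `CSc1ccc(CNc2nc([SeH])nc3ccccc23)cc1` and compound 2 `COc1ccc(CNc2nc(SC)nc3ccccc23)cc1` were both tested in a functional assay on HT-29 cells (Homo sapiens) for cytotoxicity, read by MTT assay, with a stated time of 72 h; on this read-out lower numbers stand for higher toxicity in this test and higher numbers for lower toxicity in this test. In this assay compound 1 reaches only the limit of > 100000 nM. In this assay compound 2 likewise gives only the limit of > 100000 nM. For the measured compounds named here, compound 2 thus stands where every number so far stands: the limit of > 100000 nM in this assay, at which 2 of the 2 values shown sit. Compound 3 `CSc1ccc(CNc2nc(SC)nc3ccccc23)cc1` differs from compound 2 by methylsulfanyl in place of methoxy on an aromatic carbon. Going by the values given here, with no measured step between compounds to lean on, the estimated step from compound 2 to compound 3 is a step that the limit leaves unreadable from compound 2 to compound 3, none beyond the scatter. Compound 3 is therefore expected to give 150000 nM, within a range from 50000 nM to 500000 nM, most likely again reported only as a limit.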

Compound 3, concentration lethal to 50% of the cells: > 100000 nM
Compound 3: a limit, no number; the forecaster's own chance of this, stated with the estimate: 85%; the middle value lies beyond the limit too.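

No step among compound 1, compound 2 and compound 3 can be read, since each gives only a limit: the limit of > 100000 nM in this assay, at which 3 of the 3 values shown sit.

The compounds shown leave open whether methylsulfanyl in place of methoxy changes the cytotoxicity at all.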